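The source may report more compounds than this note shows. Statements on the series, on what has been measured and on what is new or still open speak of the compounds shown alone.

Compound 2 `Cc1cc(S(N)(=O)=O)ccc1NC(=O)COc1ccc(F)cc1Oc1ccc2ccccc2c1` was examined in an ADME assay on C8166 cells (Homo sapiens) for cytotoxicity, read by MTT assay (a lower number here means that less compound is tolerated, a higher number that more compound is tolerated), where compound 2 gives 68600 nM. Among the two compounds measured so far it gives the highest number; its nearest neighbour is compound 1 `Cc1cc(S(N)(=O)=O)ccc1NC(=O)COc1ccc(F)cc1Oc1cccc2ccccc12`, which in this assay gives 33100 nM. Among the measured compounds shown here, the only measured step, a 2.1-fold higher number from compound 1 to compound 2 (0.32 log units; beyond the scatter), concerns the exchange of one naphthyl isomer for the other and goes with the change of naphthalen-1-yl to naphthalen-2-yl on the ether oxygen. Compound 3 `Cc1cc(S(N)(=O)=O)ccc1NC(=O)COc1ccc(F)cc1Oc1cc2ccccc2cc1C` is the next compound in line; it differs from compound 2 by methyl in place of hydrogen on an aromatic carbon. For the measured compounds named here, no measured step concerns a methyl added in this way, so the one step available offers only a rough guide to the size of such a change, and for compound 3 in this assay the expected step is a 1.2-fold lower number from compound 2 to compound 3 (0.10 log units; within the scatter), nothing beyond the scatter. Compound 3 is therefore estimated at 55000 nM, within a range of 25000 nM to 120000 nM.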

Compound 3, half-maximal cytotoxic concentration: 66900 nM
Compound 3: middle estimate off by 1.2-fold (0.09 log units), on the low side; low and high end bracket the measured number.
By their numbers in this assay, from the lowest: compound 1; then compounds 3 and 2 (each within the scatter of the next).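

Going from naphthalen-2-yl to 3-methylnaphthalen-2-yl, with the methyl on an aromatic carbon ortho to a large group, gives a 1.0-fold lower number from compound 2 to compound 3 (0.01 log units; within the scatter) in this assay, so at this position the added methyl brings no change that can be told from the scatter. The separation from the naphthalen-1-yl compound remains, at a 2.0-fold higher number from compound 1 to compound 3 (0.31 log units; beyond the scatter), a modest step beyond the scatter. No outside measurement is available to explain this result.

On these data alone, whether an ethyl, a methoxy, an amine or a carboxylic acid at the same position would also leave the number within the scatter remains open. So does whether the same methyl would have a similarly small effect on the naphthalen-1-yl compound.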